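The source may hold more compounds than are shown below. What is called first, only, known or untested is meant among the compounds shown, and "the series" means these compounds.

Of the compounds shown here, three have been measured in a functional assay on HepG2 cells (Homo sapiens) for inhibition, read by MTT assay, with a stated time of 48 h; on this read-out lower numbers stand for stronger inhibition and higher numbers for weaker inhibition. Compound 1 `C[Se]c1ccc(N(C)c2nc(C3CC3)nc3ccccc23)cc1` gives 32 nM, compound 2 `Cc1nc(N(C)c2ccc([Se]C#N)c(Cl)c2)c2ccccc2n1` gives 12 nM, and compound 3 `C[Se]c1ccc(N(C)c2nc(C)nc3ccccc23)cc1Cl` gives 4 nM. Compound 3 and compound 2 share a core and differ in one place (cyano in place of methyl on a selenium), which made a 3.0-fold higher number from compound 3 to compound 2 (0.48 log units; beyond the scatter). The difference between the core of compound 1 and the core of compound 3 is not broken down here. Compound 4 `CN(c1ccc([Se]C#N)cc1)c1nc(C2CC2)nc2ccccc12` is not yet measured; it differs from compound 1 in the same way (cyano in place of methyl on a selenium), the place being the same word for word. Compound 4 is therefore expected to show a 3.0-fold higher number from compound 1 to compound 4 (0.48 log units; beyond the scatter), because the same change gave a 3.0-fold higher number from compound 3 to compound 2 (0.48 log units; beyond the scatter) in this assay. Within the data shown here, that expectation is only one observed step on a different core, so for compound 4 the estimate is 96 nM, likely between 40 nM and 250 nM.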

Compound 4, half-maximal inhibitory concentration: 41 nM
For compound 4 the middle estimate is 2.3-fold (0.37 log units) above the measured one, and the stated range covers the measured number.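

On the core of compound 1, cyano in place of methyl on the selenium gives a 1.3-fold higher number from compound 1 to compound 4 (0.11 log units; within the scatter). Set beside the same change on the other core, the two steps cannot be told apart: the same change on two cores in this assay, a 3.0-fold higher number (0.48 log units; beyond the scatter) from compound 3 to compound 2 and a 1.3-fold higher number (0.11 log units; within the scatter) from compound 1 to compound 4, 2.3-fold (0.37 log units) apart, within the scatter of two such steps

Among these compounds, this shows that the change behaved compatibly on these two cores, but with only two pairs, it does not show that the step has one fixed size or that it would hold on any further core. The compounds shown leave open how a longer chain or an amine on the selenium would compare with methyl and cyano. They also leave open whether any single difference between the two cores affects the size of the step.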